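Two fluorines in place of two methoxy groups on the ketone ring

The compounds below may be only part of what the source reports. "The series", "measured", "known", "first", "only" and "open" are said of these compounds alone.

Compound 1 `COc1cc(-c2cc(/C=C/C(=O)c3ccc(N)cc3)[nH]n2)cc(OC)c1OC` and compound 2 `COc1ccc(C(=O)/C=C/c2cc(-c3cc(OC)c(OC)c(OC)c3)n[nH]2)cc1OC` share one core and differ only in the ring attached to the carbonyl carbon. In a functional assay on SK-MEL-2 cells (Homo sapiens) for inhibition, read by sulforhodamine B assay, with a stated time of 48 h (on this read-out higher numbers stand for weaker inhibition of growth and lower numbers for stronger inhibition of growth), compound 1 gives 2850 nM, while compound 2 gives 1850 nM. Compound 2 has the lower of the two numbers, but the step of a 1.5-fold lower number from compound 1 to compound 2 (0.19 log units; within the scatter) lies within the scatter of repeated measurements, so the two compounds cannot be told apart on these data.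

Compound 3 `COc1cc(-c2cc(/C=C/C(=O)c3ccc(F)c(F)c3)[nH]n2)cc(OC)c1OC` carries the change (3,4-difluorophenyl in place of 3,4-dimethoxyphenyl on a carbonyl carbon). Going by the values given here, the only measured step that touches the same place, a 1.5-fold lower number from compound 1 to compound 2 (0.19 log units; within the scatter), stayed within the scatter, so the one earlier exchange of the ring on the carbonyl carbon produced no clear shift. On that basis compound 3 is expected to move by only about a 1.3-fold higher number from compound 2 to compound 3 (0.11 log units; within the scatter) in this assay, with no direction beyond the scatter. Compound 3 is therefore estimated at 2400 nM, with a range from 900 nM to 6500 nM.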

Compound 3, concentration for 50% growth inhibition: 2300 nM
Compound 3: middle estimate off by 1.0-fold (0.02 log units), on the high side; the measured number falls inside the stated range.
By their numbers in this assay, from the lowest: compounds 2, 3 and 1 (each within the scatter of the next).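

The step of a 1.2-fold higher number from compound 2 to compound 3 (0.09 log units; within the scatter) and the step of a 1.2-fold lower number from compound 1 to compound 3 (0.09 log units; within the scatter) both hold for this assay and complete the set of comparisons among the three compounds. The carbonyl carbon has now carried 3,4-difluorophenyl as well, a ring with 0 hydrogen-bond acceptors where 3,4-dimethoxyphenyl has 2, and all three compounds still cannot be told apart on these numbers. This means that, among these three compounds, swapping methoxy groups for fluorines on this ring gives no readable shift, and no measurement is at hand to explain that.

Open, going by these compounds, is whether any group at this place can move the number beyond the scatter, for example a ring bearing a carboxylic acid, or a plain methyl group in place of the ring. Also open, on these data alone, is whether the same flat result would hold in any other cell line.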